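Halogen change on the phenyl ring: expectation for compound 3

The compounds below may be only part of what the source reports. "The series", "measured", "known", "first", "only" and "open" are said of these compounds alone.

Measured so far:
compound 1 `O=C(Nc1ccc(Cl)cc1)N1CCC[C@H]1c1nc(-c2cccc(Br)c2)no1`: > 50000 nM
compound 2 `O=C(Nc1ccc(Cl)cc1)N1CCC[C@H]1c1nc(-c2ccc(F)cc2)no1`: > 50000 nM

Compound 1 `O=C(Nc1ccc(Cl)cc1)N1CCC[C@H]1c1nc(-c2cccc(Br)c2)no1` carries 3-bromophenyl. In an ADME assay on MCF-10A cells (Homo sapiens) for inhibition, with a stated time of 48 h (on this read-out higher numbers stand for weaker inhibition and lower numbers for stronger inhibition), compound 1 gives > 50000 nM, which is a limit of the assay and not a number. Compound 2 `O=C(Nc1ccc(Cl)cc1)N1CCC[C@H]1c1nc(-c2ccc(F)cc2)no1` carries 4-fluorophenyl in place of 3-bromophenyl on an aromatic carbon. In this assay compound 2 gives > 50000 nM, again a limit and not a number. The step from compound 1 to compound 2 is a step that the two limits leave unreadable from compound 1 to compound 2. On the numbers shown compound 2 stands only at a limit, and the one further value shown is a limit as well; the limit of > 50000 nM in this assay, at which 2 of the 2 values shown sit, describes where both sit.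

Compound 3 `O=C(Nc1ccc(Cl)cc1)N1CCC[C@H]1c1nc(-c2ccc(I)cc2)no1` differs from compound 2 by iodo in place of fluoro on an aromatic carbon. Among the compounds with values here, the only measured step in this assay bears on it, and its size could not be read. Within the data shown here, no step of readable size is therefore expected from compound 2 to compound 3: a number no higher from compound 2 to compound 3 (the limit leaves the size open) is the estimate. Compound 3 is expected at 50000 nM in this assay, within 15000 nM to 150000 nM, and most probably again reported only as a limit.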

Compound 3, half-maximal inhibitory concentration: > 50000 nM
Compound 3: no number, only a limit; the forecaster's own chance of this, stated with the estimate: 80%; the middle value lies on the limit itself.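

In this assay compound 3 gives > 50000 nM, a limit of the assay and not a number. Within the data shown here, no step among compound 1, compound 2 and compound 3 can be read: the limit of > 50000 nM in this assay, at which 3 of the 3 values shown sit. The compounds shown leave open whether changing the halogen on the phenyl ring alters the read-out at all.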